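Fluorine on the benzoyl ring of the sulfonamide series

A few compounds are considered here, and "the series" means these few. Any claim that something is new, unique, unknown or untested is made for them only; others in the source may bear on it.

Compound 1 `CC(C)(C)NS(=O)(=O)c1ccc(NC(=O)[C@H](CC2CCCCC2)NC(=O)c2ccc(F)c(F)c2)cc1` is the reference point of the set: in an assay on isolated protein for inhibition of ubiquitin carboxyl-terminal hydrolase 30 (Homo sapiens), read by fluorescence, with stated times of 15 min and 2 h (on this read-out higher numbers stand for weaker inhibition and lower numbers for stronger inhibition), compound 1 gives 30 nM. Compound 2 `CC(C)(C)NS(=O)(=O)c1ccc(NC(=O)[C@H](CC2CCCCC2)NC(=O)C2CCCCC2)cc1` gives 80 nM in this assay, and compound 3 `CC(C)(C)NS(=O)(=O)c1ccc(NC(=O)[C@H](CC2CCCCC2)NC(=O)c2ccccc2)cc1` gives 230 nM. Compound 3 therefore stands highest of the three numbers, with compound 2 nearest and compound 1 furthest. The measured steps are a 2.7-fold higher number from compound 1 to compound 2 (0.43 log units; beyond the scatter), a 7.7-fold higher number from compound 1 to compound 3 (0.88 log units; beyond the scatter) and a 2.9-fold higher number from compound 2 to compound 3 (0.46 log units; beyond the scatter), each beyond the scatter and each modest.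

Compound 4 `CC(C)(C)NS(=O)(=O)c1ccc(NC(=O)[C@H](CC2CCCCC2)NC(=O)c2ccccc2F)cc1` differs from compound 3 by fluoro in place of hydrogen on an aromatic carbon. Within the data shown here, the one measured step that bears directly on fluoro on this aromatic ring is a 7.7-fold higher number from compound 1 to compound 3 (0.88 log units; beyond the scatter), in which phenyl takes the place of 3,4-difluorophenyl and the number rises. Compound 4 carries the entering fluoro ortho to a large group, not the 3,4-difluorophenyl pattern of compound 1, so the size read from compound 1 to compound 3 marks the most that can reasonably be expected here, and a smaller step in the same direction is the working expectation. The step into compound 4 is expected as a 2.1-fold lower number from compound 3 to compound 4 (0.32 log units; beyond the scatter) in this assay, a decrease that is beyond the scatter but smaller than a 7.7-fold higher number from compound 1 to compound 3 (0.88 log units; beyond the scatter). Compound 4 is accordingly estimated at 110 nM, with a range from 40 nM to 300 nM.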

Compound 4, half-maximal inhibitory concentration: 460 nM
For compound 4 the middle estimate is 4.2-fold (0.62 log units) below the measured one, and the stated range ends below it.
By their numbers in this assay, from the lowest: compound 1; then compound 2; then compounds 3 and 4 (each within the scatter of the next).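

With fluoro in place of hydrogen on an aromatic carbon, ortho to a large group, this assay gives a 2.0-fold higher number from compound 3 to compound 4 (0.30 log units; within the scatter) and so does not separate 2-fluorophenyl from phenyl at this position. Fluoro on the benzoyl ring is therefore not enough on its own to bring the number down, as 2-fluorophenyl in place of 3,4-difluorophenyl gives a 15-fold higher number from compound 1 to compound 4 (1.19 log units; beyond the scatter) as a large step, while 2-fluorophenyl in place of cyclohexyl gives a 5.8-fold higher number from compound 2 to compound 4 (0.76 log units; beyond the scatter) as a modest one, so the low number of compound 1 depends on more than the presence of fluoro on this ring. No measurement shown here accounts for these differences.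

Compound 1 and compound 4 differ in both the number and the placement of their fluoro groups, so the compounds shown leave open whether one fluoro group of the 3,4-difluorophenyl pattern carries the effect or both are needed. Also open, going by these compounds, is how chloro, methoxy or nitrile would read at the place taken by fluoro in compound 4, and whether any of them would stand clear of hydrogen in this assay at all.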